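A few compounds are considered here, and "the series" means these few. Any claim that something is new, unique, unknown or untested is made for them only; others in the source may bear on it.

In a functional assay on HeLa cells (Homo sapiens) for antiproliferative activity, read by MTT assay, with a stated time of 72 h (a lower number here means a stronger inhibitor, a higher number a weaker inhibitor), three compounds have been measured so far. Compound 1 `COc1cc(C(=O)c2sc3ccccc3c2-c2ccc(F)cc2)cc(OC)c1OC` gives 3000 nM, compound 2 `COc1cc(C(=O)c2sc3ccccc3c2-c2ccc(Cl)cc2)cc(OC)c1OC` gives 5200 nM, and compound 3 `COc1ccc(-c2c(C(=O)c3cc(OC)c(OC)c(OC)c3)sc3ccccc23)c(OC)c1` gives 3900 nM. Compound 2 carries the highest of the three numbers, yet its nearest neighbour is compound 3 at a 1.3-fold lower number from compound 2 to compound 3 (0.12 log units; within the scatter), and compound 1 stands at a 1.7-fold higher number from compound 1 to compound 2 (0.24 log units; within the scatter), both within the scatter, so nothing sets compound 2 apart from the other two.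

Compound 4 `COc1ccc(-c2c(C(=O)c3cc(OC)c(OC)c(OC)c3)sc3ccccc23)cc1C` has not yet been measured. It differs from compound 2 by 4-methoxy-3-methylphenyl in place of 4-chlorophenyl on an aromatic carbon. The step that bears most on this change is the replacement of the same 4-chlorophenyl by 2,4-dimethoxyphenyl, a 1.3-fold lower number from compound 2 to compound 3 (0.12 log units; within the scatter), which lay within the scatter; the exchange of chloro for fluoro, a 1.7-fold higher number from compound 1 to compound 2 (0.24 log units; within the scatter), and of 4-fluorophenyl for 2,4-dimethoxyphenyl, a 1.3-fold higher number from compound 1 to compound 3 (0.11 log units; within the scatter), were likewise within the scatter. Every variation of this aryl group among the three measured compounds has left this assay unmoved, so no step beyond the scatter is expected for compound 4, a 1.3-fold lower number from compound 2 to compound 4 (0.11 log units; within the scatter). The estimate for compound 4 is therefore 4000 nM, within 1800 nM to 9000 nM.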

Compound 4, half-maximal inhibitory concentration: 10000 nM
Beside the measured number, compound 4's estimate is 2.5-fold (0.40 log units) below it, outside the stated range (above it).
By their numbers in this assay, from the lowest: compounds 1, 3, 2 and 4 (each within the scatter of the next, the first and the last beyond it).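

In this assay, among the compounds shown here, the aryl group at this position is no longer without effect: 4-methoxy-3-methylphenyl gives a 2.6-fold higher number from compound 3 to compound 4 (0.41 log units; beyond the scatter) and a 3.3-fold higher number from compound 1 to compound 4 (0.52 log units; beyond the scatter), the first steps here to lie beyond the scatter, while a 1.9-fold higher number from compound 2 to compound 4 (0.28 log units; within the scatter) stays within it. The position on the five-membered ring, two ring bonds from the ring sulfur, therefore does respond to the choice of aryl group, though only modestly and only against two of the three earlier groups. Nothing measured here accounts for this shift.

As far as these compounds go, it remains open whether the methyl or the methoxy of the entering group carries the step, which a phenyl bearing only one of them would separate. Also open, from the compounds shown here alone, is how this assay would respond to an amine or a carboxylic acid on this aryl ring.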